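Trifluoromethyl in place of methoxy: an expected step

The compounds below may be only part of what the source reports. "The series", "measured", "known", "first", "only" and "open" are said of these compounds alone.

Compounds measured so far:
compound 1, `Cc1ccc(-n2cnc3cc(C(=O)N4CCCCC4)ccc32)cc1`, giving 19 nM in an assay on isolated protein for inhibition of 15-hydroxyprostaglandin dehydrogenase [NAD(+)] (Homo sapiens), read by fluorescence, with a stated time of 15 min; on this read-out lower numbers stand for stronger inhibition and higher numbers for weaker inhibition
compound 2, `COc1ccc(-n2cnc3cc(C(=O)N4CCCCC4)ccc32)cc1`, giving 19 nM in this assay

Compound 2 stands level with compound 1: the step of no change at the digits printed from compound 1 to compound 2 (within the scatter), which exchanged methyl for methoxy on an aromatic carbon, lies within the scatter of this assay. Compound 3, `O=C(c1ccc2c(c1)ncn2-c1ccc(C(F)(F)F)cc1)N1CCCCC1`, is the next change from compound 2: trifluoromethyl in place of methoxy on an aromatic carbon. Among the measured compounds shown here, only one measured step bears on this change, the one from compound 1 to compound 2, and it produced nothing beyond the scatter although the group on that aromatic carbon was exchanged. For the measured compounds named here, no measured step shows what a trifluoromethyl does at this place, so that single comparison is the only guide. The step of no change at the digits printed from compound 2 to compound 3 (within the scatter) is therefore expected to stay within the scatter. For compound 3 the estimate in this assay is 19 nM, with a range from 7 nM to 50 nM.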

Compound 3, half-maximal inhibitory concentration: 86 nM
Compound 3: the middle estimate sits 4.5-fold (0.66 log units) below what was measured; the measured number lies above the stated range.
By their numbers in this assay, from the lowest: compounds 1 and 2 (each within the scatter of the next); then compound 3.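

This position, para to a large group, is not indifferent to what it carries: in this assay there is a 4.5-fold higher number from compound 2 to compound 3 (0.66 log units; beyond the scatter), and likewise a 4.5-fold higher number from compound 1 to compound 3 (0.66 log units; beyond the scatter). Methyl and methoxy sit level with each other, so their match did not hold for every group, and trifluoromethyl, with 4 heavy atoms against 2 for methoxy and no hydrogen-bond acceptor, is the one group of the three that gives weaker inhibition. Nothing measured here explains this loss.

Still open, going by these compounds, is whether the loss belongs to trifluoromethyl alone or would also appear with a single chlorine atom, a nitrile or an amine on the same aromatic carbon. Three groups at one place also cannot show how a longer chain, such as ethyl or propyl, would behave there.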